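The Same Amide Change on a Rearranged Core

A few compounds are considered here, and "the series" means these few. Any claim that something is new, unique, unknown or untested is made for them only; others in the source may bear on it.

Measured compounds:
- compound 1 `CCCCC(=O)c1ccc(C(CC)(CC)c2ccc(C#CC(O)(CC)CC)c(C)c2)n1CC`: > 50 nM
- compound 2 `CCn1c(C(=O)NCC(=O)O)ccc1C(CC)(CC)c1ccc(C#CC(O)(CC)CC)c(C)c1`: 9.36 nM
- compound 3 `CCCCC(=O)c1cc(C(CC)(CC)c2ccc(C#CC(O)(CC)CC)c(C)c2)cn1CC`: > 50 nM

Compound 1 and compound 3 are built from the same atoms joined differently; the difference between the two cores is not broken down here. In an assay on cells for agonist activity at vitamin D3 receptor (Homo sapiens), read by microscopy (a higher number here means that more compound is needed for the effect, a lower number that less compound is needed), compound 1 gives only a limit of the assay, > 50 nM. Compound 3 likewise gives only a limit in this assay, > 50 nM. Compound 2, in contrast, gives a number, 9.36 nM.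

Going by the values given here, the one measured step is the change from compound 1 to compound 2, ((carboxymethyl)amino in place of butyl on a carbonyl carbon). It made an at least 5.3-fold lower number from compound 1 to compound 2 (0.72 log units; beyond the scatter). Because compound 1 sits at the limit of > 50 nM in this assay, at which 2 of the 3 values shown sit, the true size of that step can only be given as a lower bound.

Compound 4 `CCn1cc(C(CC)(CC)c2ccc(C#CC(O)(CC)CC)c(C)c2)cc1C(=O)NCC(=O)O` carries the same change on the core of compound 3: (carboxymethyl)amino in place of butyl on a carbonyl carbon. The place, a carbonyl carbon whose other neighbour is an aromatic carbon, reads the same in both cases, so this is the same change, now on the rearranged core, and it is the second of the two occurrences among these compounds.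

Since compound 3 also stands at the limit, the step from compound 3 to compound 4 is expected to be an at least 2.5-fold lower number from compound 3 to compound 4 (0.39 log units; beyond the scatter), by analogy to the step from compound 1 to compound 2, with the core difference left unresolved. Compound 4 is therefore estimated at 20 nM in this assay, within 4 nM to 100 nM.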

Compound 4, half-maximal effective concentration: 54.3 nM
Estimate against measurement, compound 4: 2.7-fold (0.43 log units) below, within the range that was stated.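

In this assay compound 3 gives > 50 nM as a limit of the assay. Compound 4 gives 54.3 nM as a number. The step from compound 3 to compound 4 cannot be read, because compound 3 stands at a limit: the limit of > 50 nM in this assay, at which 2 of the 4 values shown sit. The compounds shown leave open the true size of the change from butyl to (carboxymethyl)amino on either core, and how the two cores differ.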